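The source may report more compounds than this note shows. Statements on the series, on what has been measured and on what is new or still open speak of the compounds shown alone.

Measured so far:
compound 1 `Cc1cccc(CSc2cc(Cl)c(C)cc2S(=O)(=O)/N=C(\N)N/N=C/C#Cc2ccccc2)c1`: 0.879 h
compound 2 `C/C(C#Cc1ccccc1)=N\N/C(N)=N/S(=O)(=O)c1cc(C)c(Cl)cc1SCc1cccc(C(F)(F)F)c1`: 0.13 h

In an ADME assay on microsomes from liver (Homo sapiens) for metabolic stability, read by LC-MS, using NADPH, tested at 5 uM (on this read-out higher numbers stand for a longer-lived compound and lower numbers for a shorter-lived compound), compound 1 gives 0.879 h, the higher of the two numbers shown. Compound 2 gives 0.13 h, a gap from compound 1 that lies beyond the scatter. Among the compounds with values here, compound 2 differs from compound 1 in more than one place, so no single step is drawn between them.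

The next compound, compound 3 `Cc1cc(S(=O)(=O)/N=C(\N)N/N=C/C#Cc2ccccc2)c(SCc2cccc3ccccc23)cc1Cl`, remains to be measured in this assay. It differs from compound 1 by naphthalen-1-yl in place of 3-methylphenyl on a saturated chain carbon bound to a sulfur. Within the data shown here, no measured pair isolates this change, so the direction of the step rests on no precedent. The step is expected to be modest, most likely downward, and it may fall within the scatter; the estimated step is a 1.6-fold lower number from compound 1 to compound 3 (0.20 log units; within the scatter). Compound 3 is accordingly estimated at 0.55 h, with an expected range from 0.2 h to 1.5 h.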

Compound 3, half-life: 1.2 h
Compound 3: the middle estimate sits 2.2-fold (0.34 log units) below what was measured; low and high end bracket the measured number.
By their numbers in this assay, from the lowest: compound 2; then compounds 1 and 3 (each within the scatter of the next).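

In this assay, within the data shown here, a 1.4-fold higher number from compound 1 to compound 3 (0.14 log units; within the scatter) is the first step read at a single place, on a saturated chain carbon bound to a sulfur, and it leaves compound 1 and compound 3 indistinguishable. At this place, then, naphthalen-1-yl, with its second six-membered aromatic ring, can stand in for 3-methylphenyl with no change in half-life beyond the scatter, a finding that rests on this one pair alone. No measured property of either group accounts for this outcome.

Still open, going by these compounds, is how this place responds to a group of another kind, such as an amine, a carboxylic acid or a longer chain in place of the aromatic ring. Also open, on these data alone, is whether the same change reads alike when the rest of the molecule differs from compound 1.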